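Swapping the Isopropyl Imidazole for a Dimethyl Imidazole

The source may hold more compounds than are shown below. What is called first, only, known or untested is meant among the compounds shown, and "the series" means these compounds.

Compound 1 `CCC(C)n1ncn(-c2ccc(N3CCN(c4ccc(OC[C@@H]5CO[C@@](Cc6ccccc6)(c6ccc(Cl)cc6Cl)O5)cc4)CC3)cc2)c1=O`: 513 nM
Compound 2 `CCC(C)n1ncn(-c2ccc(N3CCN(c4ccc(OC[C@@H]5CO[C@@](Cn6nc(C)nc6C)(c6ccc(Cl)cc6Cl)O5)cc4)CC3)cc2)c1=O`: 221 nM
Compound 3 `CCC(C)n1ncn(-c2ccc(N3CCN(c4ccc(OC[C@@H]5CO[C@@](Cn6ccnc6C(C)C)(c6ccc(Cl)cc6Cl)O5)cc4)CC3)cc2)c1=O`: 84 nM

These values come from a functional assay on HUVEC cells (Homo sapiens), read by scintillation counting and thymidine incorporation, with a stated time of 24 h; on this read-out lower numbers stand for stronger inhibition and higher numbers for weaker inhibition. Among the three, compound 3 has the lowest number, and its steps to both others lie beyond the scatter.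

The next molecule, compound 4 `CCC(C)n1ncn(-c2ccc(N3CCN(c4ccc(OC[C@@H]5CO[C@@](Cn6cc(C)nc6C)(c6ccc(Cl)cc6Cl)O5)cc4)CC3)cc2)c1=O`, keeps the shared core and alters one group: 2,4-dimethyl-1H-imidazol-1-yl in place of 2-isopropyl-1H-imidazol-1-yl on a saturated chain carbon bound to a saturated ring carbon. In words, 2,4-dimethyl-1H-imidazol-1-yl stands in place of 2-isopropyl-1H-imidazol-1-yl on a saturated chain carbon bound to a saturated ring carbon.

Within the data shown here, no measured step makes this exact swap, so the evidence is indirect. Replacing phenyl gave a 2.3-fold lower number from compound 1 to compound 2 (0.37 log units; beyond the scatter) with the triazole group and a 6.1-fold lower number from compound 1 to compound 3 (0.79 log units; beyond the scatter) with the imidazole group. The change of group then gave a 2.6-fold lower number from compound 2 to compound 3 (0.42 log units; beyond the scatter), so these related groups differ only modestly. Compound 4 shares its imidazole ring with compound 3 and its pair of methyl groups with compound 2. A number in the gap from compound 3 at 84 nM to compound 2 at 221 nM therefore seems likely, nearer the lower end.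

The expected change is a 1.5-fold higher number from compound 3 to compound 4 (0.17 log units; within the scatter), a small rise that may stay within the scatter.

For compound 4 the estimated value is 125 nM, with an expected range of 50 nM to 310 nM.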

Compound 4, half-maximal inhibitory concentration: 492 nM
For compound 4 the middle estimate is 3.9-fold (0.60 log units) below the measured one; the measured number lies above the stated range.
By their numbers in this assay, from the lowest: compound 3; then compound 2; then compounds 4 and 1 (each within the scatter of the next).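

In this assay the imidazole ring alone does not secure the low number of compound 3: the step to the new group is large (a 5.9-fold higher number from compound 3 to compound 4 (0.77 log units; beyond the scatter)), even though both groups are imidazoles on a saturated chain carbon bound to a saturated ring carbon. The new group also falls behind the triazole group (a 2.2-fold higher number from compound 2 to compound 4 (0.35 log units; beyond the scatter)) and cannot be told apart from phenyl (a 1.0-fold lower number from compound 1 to compound 4 (0.02 log units; within the scatter)), so among these four compounds the ring type gives no simple ranking, since the triazole group of compound 2 lies on one side of the imidazole group of compound 3 and on the other side of the imidazole group of compound 4. None of the information at hand explains why these closely related groups differ.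

Going from 2-isopropyl-1H-imidazol-1-yl to 2,4-dimethyl-1H-imidazol-1-yl changes two things at once, so the compounds shown cannot say how much of the step belongs to the shorter isopropyl-to-methyl substituent and how much to the added methyl group. A compound carrying 2-methyl-1H-imidazol-1-yl, or 2-isopropyl-4-methyl-1H-imidazol-1-yl, would separate those two changes.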